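The source may report more compounds than this note shows. Statements on the series, on what has been measured and on what is new or still open speak of the compounds shown alone.

In a functional assay on MGC-803 cells (Homo sapiens) for antiproliferative activity, read by MTT assay, with a stated time of 48 h (a lower number here means a stronger inhibitor, a higher number a weaker inhibitor), compound 1 (`CCCCCCCCCn1cc(COC[C@@H]2OC[C@H](N)[C@@H]2O)nn1`) gives 13800 nM. Compound 2 (`CCCCCCCCn1cc(COC[C@@H]2OC[C@H](N)[C@H]2O)nn1`) gives > 128000 nM, which is a limit of the assay and not a number. Compound 2 therefore stands on a limit alone, and any step from it starts without a measured value. Compound 3 (`CCCCCCCCCn1cc(COC[C@@H]2OC[C@H](N)[C@H]2O)nn1`) differs from compound 2 by methyl in place of hydrogen on a saturated chain carbon, eight bonds along the chain from an aromatic nitrogen. For the measured compounds named here, no measured step shows what this change does in this assay. Going by the values given here, the one numerical guide is compound 1 at 13800 nM, so a move towards stronger inhibition is expected, though its size is uncertain. The estimated change is an at least 2.5-fold lower number from compound 2 to compound 3 (0.40 log units; beyond the scatter). For compound 3 the expected value is 50000 nM, with an estimated range of 15000 nM to 128000 nM.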

Compound 3, half-maximal inhibitory concentration: > 128000 nM
Compound 3: only a limit was reported; the forecaster's own chance of this, stated with the estimate: 35%; middle value at least 2.5-fold (0.40 log units) away from the limit.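

With methyl in place of hydrogen on a saturated chain carbon, eight bonds along the chain from an aromatic nitrogen, compound 3 in this assay gives > 128000 nM, which is a limit of the assay and not a number. The step from compound 2 to compound 3 cannot be read, so the size of this change stays unknown, as both compounds rest on a limit: the limit of > 128000 nM in this assay, at which 2 of the 3 values shown sit. The chain alone therefore does not bring a measured value here, whereas an at least 9.2-fold higher number from compound 1 to compound 3 (0.96 log units; beyond the scatter) ties the difference to a single stereocentre: the fact that compounds 1 and 3 differ only in the configuration as drawn

The compounds shown leave open whether a longer chain would bring the configuration of compound 3 to a measurable value. They also leave open whether an amine or a carboxylic acid on the chain would do so.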